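A few compounds are considered here, and "the series" means these few. Any claim that something is new, unique, unknown or untested is made for them only; others in the source may bear on it.

Among the compounds with values here, compound 2 `COc1cccc(CNCCCNS(=O)(=O)c2cc(C(F)(F)F)cc(C(F)(F)F)c2)c1` gives 1700 nM in a functional assay on BXPC-3 cells (Homo sapiens) for inhibition, read by MTT assay, with a stated time of 72 h (on this read-out higher numbers stand for weaker inhibition of growth and lower numbers for stronger inhibition of growth), the lower of the two numbers so far; compound 1 `COc1ccc(CNCCCNS(=O)(=O)c2cc(C(F)(F)F)cc(C(F)(F)F)c2)cc1OC` gives 13000 nM. Within the data shown here, the only measured step, a 7.6-fold lower number from compound 1 to compound 2 (0.88 log units; beyond the scatter), removed one methoxy. Compound 3 `O=S(=O)(NCCCNCc1ccc(Cl)cc1)c1cc(C(F)(F)F)cc(C(F)(F)F)c1` differs from compound 2 by 4-chlorophenyl in place of 3-methoxyphenyl on a saturated chain carbon bound to an amine nitrogen: the remaining methoxy leaves and a chlorine enters. Among the measured compounds shown here, that single step is the only guide, and it pointed downward; a step of similar or smaller size is expected, though the entering chlorine has no measured counterpart. Compound 3 is therefore estimated at 1000 nM, range 300 nM to 3500 nM, an expected step of a 1.7-fold lower number from compound 2 to compound 3 (0.23 log units; within the scatter).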

Compound 3, concentration for 50% growth inhibition: 1600 nM
Estimate against measurement, compound 3: 1.6-fold (0.20 log units) below, and the stated range covers the measured number.
By their numbers in this assay, from the lowest: compounds 3 and 2 (each within the scatter of the next); then compound 1.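

In this assay the exchange of 3-methoxyphenyl for 4-chlorophenyl on a saturated chain carbon bound to an amine nitrogen gives a 1.1-fold lower number from compound 2 to compound 3 (0.03 log units; within the scatter) and so leaves no readable change. The methoxy group of compound 2 is therefore not required at this position, since a chlorine-bearing ring serves equally here. The step of an 8.1-fold lower number from compound 1 to compound 3 (0.91 log units; beyond the scatter) places compound 1 apart from both. No available evidence accounts for these numbers.

The exchange alters both the substituent and its ring position, so their contributions remain unseparated; 3-chlorophenyl would separate them. As far as these compounds go, a longer chain in the shared core also remains open.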